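The source may report more compounds than this note shows. Statements on the series, on what has been measured and on what is new or still open speak of the compounds shown alone.

Measured so far in a functional assay on the whole organism (Tail, strain ICR) with Mus musculus as the target, in the tail flick test, with a stated time of 150 min, at a dose of 12.5 umol/kg by the oral route; on this read-out higher numbers stand for a stronger effect at the one dose given and lower numbers for a weaker effect:

Compound 1, `N=C(N)NCCC[C@H](NC(=O)CN(c1nc(Cl)nc2[nH]cnc12)C1CC1)C(=O)O`, gives 6.93%.
Compound 2, `NCCCC[C@H](NC(=O)CN(c1nc(Cl)nc2[nH]cnc12)C1CC1)C(=O)OCc1ccccc1`, gives 9.91%.

Compound 2 holds the higher of the two numbers, yet its gap to compound 1 lies within the scatter, so the two results cannot be told apart. Compound 3, `NCCCC[C@H](NC(=O)CN(c1nc(Cl)nc2[nH]cnc12)C1CC1)C(=O)O`, differs from compound 2 in one place: hydrogen in place of benzyl on an oxygen next to a carbonyl group. Within the data shown here, no measured pair shows this change, so no size for it is known. The step of a number 2.9 percentage points lower from compound 2 to compound 3 (within the scatter) is expected to stay within the scatter. Compound 3 is therefore estimated at 7%, between 0% and 18%.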

Compound 3, a percentage reported as activity, at one dose (the size of the read-out at that dose, not a potency): 7.39%
The estimate for compound 3 lay 0.4 percentage points below the measured number, and the stated range covers the measured number.
By their numbers in this assay, from the lowest: compounds 1, 3 and 2 (each within the scatter of the next).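

In this assay, hydrogen in place of benzyl on an oxygen next to a carbonyl group gives a number 2.5 percentage points lower from compound 2 to compound 3 (within the scatter), so benzyl and hydrogen at this place cannot be told apart. A group of 2 heavy atoms in place of a group of 4 heavy atoms on a saturated chain carbon gives a number 0.5 percentage points higher from compound 1 to compound 3 (within the scatter), so these two groups cannot be told apart either. Nothing available explains these results.

Going by these compounds, whether methyl or ethyl on that oxygen would read differently stays open. So does the effect of a longer chain carrying the amine.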